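This account rests on a few compounds, and the source may have more. Where it says the series, first, only, none or still open, it means among the compounds named here.

In a functional assay on LNCaP cells (Homo sapiens) for cytotoxicity (on this read-out higher numbers stand for weaker inhibition and lower numbers for stronger inhibition), compound 1 (`O=C(Nc1ccncc1)Nc1ccc(-c2nc(N3CC4CCC(C3)O4)c3cnn(C4CCC5(CC4)OCCO5)c3n2)cc1`) gives 1 nM and compound 2 (`CNC(=O)Nc1ccc(-c2nc(N3CC4CCC(C3)O4)c3cnn([C@H]4CC[C@@H](O)CC4)c3n2)cc1`) gives 20 nM. Compound 2 thus has the higher of the two numbers, with a gap beyond the scatter. Compound 3 (`CNC(=O)Nc1ccc(-c2nc(N3CC4CCC(C3)O4)c3cnn(C4CCC(OC)(OC)CC4)c3n2)cc1`) differs from compound 2 in one place: a group of 10 heavy atoms (8 carbon, 2 oxygen; one six-membered non-aromatic ring of carbon only) in place of a group of 7 heavy atoms (6 carbon, 1 oxygen; one six-membered non-aromatic ring of carbon only), on an aromatic nitrogen. Among the measured compounds shown here, no measured pair isolates this change, so only a small move towards a lower number is expected in this assay, close to the scatter. The expected step is a 1.7-fold lower number from compound 2 to compound 3 (0.22 log units; within the scatter). For compound 3 the estimated value is 12 nM, with an expected range of 4 nM to 40 nM.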

Compound 3, half-maximal inhibitory concentration: 2 nM
Compound 3: middle estimate off by 6.0-fold (0.78 log units), on the high side, outside the stated range (below it).
By their numbers in this assay, from the lowest: compounds 1 and 3 (each within the scatter of the next); then compound 2.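

In this assay, among the compounds shown here, this is the first change read on its own at the aromatic nitrogen: replacing 4-hydroxycyclohexyl with the group of 10 heavy atoms, which has 0 hydrogen-bond donors and 2 hydrogen-bond acceptors, gives a 10-fold lower number from compound 2 to compound 3 (1.00 log units; beyond the scatter). The hydroxyl of compound 2 is therefore not required for a low number here. No measurement available explains this step.

For the compounds shown here, the single step cannot separate the loss of the hydroxyl from the added atoms. From the compounds shown here alone, how an amine on the same cyclohexyl ring would read remains open.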